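Anilinoquinazoline thioacetamides: the ring-nitrogen aryl changed

This account rests on a few compounds, and the source may have more. Where it says the series, first, only, none or still open, it means among the compounds named here.

Three compounds of this series have numbers in a functional assay on MDA-MB-231 cells (Homo sapiens) for inhibition, read by MTT assay, with a stated time of 72 h; on this read-out higher numbers stand for weaker inhibition and lower numbers for stronger inhibition. Compound 1 `O=C(CSc1nc(Nc2ccccc2)c2ccccc2n1)Nc1cccc(Br)c1` gives 17500 nM. Within the data shown here, compound 2 `O=C(CSc1nc(Nc2ccccc2)c2ccccc2n1)Nc1ccc(F)c(Cl)c1` gives 21600 nM; the only step measured between neighbours, a 1.2-fold higher number from compound 1 to compound 2 (0.09 log units; within the scatter), exchanges the aryl on the amide-type nitrogen. Compound 3 `C=CC(=O)Nc1cccc(NC(=O)CSc2nc(Nc3ccccc3F)c3ccccc3n2)c1` gives 18700 nM, the second highest of the three numbers, with compound 1 nearest and compound 2 furthest, both within the scatter. All three thus sit in one band in this assay.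

Compound 4 `C=CC(=O)Nc1cccc(NC(=O)CSc2nc(Nc3ccc(Cl)c(Cl)c3)c3ccccc3n2)c1` differs from compound 3 in one place: 3,4-dichlorophenyl in place of 2-fluorophenyl on a nitrogen on an aromatic ring. Among the measured compounds shown here, no measured step touches this nitrogen on the aromatic ring; the one measured step, from compound 1 to compound 2, changes the aryl on the other nitrogen and stays within the scatter. The series offers no evidence that an aryl exchange of this kind moves the number, so for compound 4 no step beyond the scatter is expected, a 1.1-fold higher number from compound 3 to compound 4 (0.03 log units; within the scatter). Compound 4 is therefore estimated at 20000 nM, with a range from 8000 nM to 50000 nM.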

Compound 4, half-maximal inhibitory concentration: 17700 nM
Beside the measured number, compound 4's estimate is 1.1-fold (0.05 log units) above it; low and high end bracket the measured number.
By their numbers in this assay, from the lowest: compounds 1, 4, 3 and 2 (each within the scatter of the next).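

In this assay, the aryl on a nitrogen on an aromatic ring now has a measured step of its own: a 1.1-fold lower number from compound 3 to compound 4 (0.02 log units; within the scatter), with 3,4-dichlorophenyl entering for 2-fluorophenyl. This exchange of one fluorine for two chlorines therefore does not separate the pair, and each of the two nitrogens bearing an aryl has now had one exchange that stays within the scatter. Nothing available explains this result.

From the compounds shown here alone, the aryl groups on this nitrogen carry only fluorine or chlorine, so it remains open whether an aryl bearing an amine or a carboxylic acid would give a step beyond the scatter. Compounds 1 and 2 differ from compounds 3 and 4 in more than one place, so the contribution of the aryl on the amide-type nitrogen in compounds 3 and 4 cannot be read.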